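The source may hold more compounds than are shown below. What is called first, only, known or untested is meant among the compounds shown, and "the series" means these compounds.

Compound 1 `CC(=O)Nc1ccc(Cc2noc(CCC(=O)Nc3ccccc3)n2)cc1` gives 34.2% in a functional assay on the whole organism (strain C57BL/6) for inhibition, with Mus musculus as the target, read by paw edema, with stated times of 1 h and 4 h, at a dose of 100 mg/kg by the oral route; on this read-out higher numbers stand for more inhibition at the one dose given (going by the name of the read-out) and lower numbers for less inhibition.
Compound 2 `COc1ccccc1NC(=O)CCc1nc(Cc2ccc(NC(C)=O)cc2)no1` gives 87.7% in this assay.

Compound 2 stands highest of the two numbers; its nearest is compound 1, with a number 53.5 percentage points higher from compound 1 to compound 2 (beyond the scatter). Compound 3 `COc1ccc(NC(=O)CCc2nc(Cc3ccc(NC(C)=O)cc3)no2)cc1` differs from compound 2 in one place: 4-methoxyphenyl in place of 2-methoxyphenyl on an amide-type nitrogen. Within the data shown here, no measured step exchanges 2-methoxyphenyl for 4-methoxyphenyl, so the only guide is a number 53.5 percentage points higher from compound 1 to compound 2 (beyond the scatter), a large step that shows the methoxy matters without showing whether its placement does. A moderate fall is therefore expected, a number 27.7 percentage points lower from compound 2 to compound 3 (beyond the scatter), with wide uncertainty. Compound 3 is estimated at 60%, in a range from 30% to 90%.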

Compound 3, a percentage reported as inhibition, in the whole organism at one dose (the size of the read-out at that dose, not a potency): 49.3%
Beside the measured number, compound 3's estimate is 10.7 percentage points above it; measured number inside the range.
By their numbers in this assay, from the lowest: compound 1; then compound 3; then compound 2.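

With the same atoms on the amide-type nitrogen, 4-methoxyphenyl in place of 2-methoxyphenyl gives a number 38.4 percentage points lower from compound 2 to compound 3 (beyond the scatter) in this assay, so the placement of the methoxy matters as well as its presence. The 4-methoxyphenyl compound still keeps a gain over the unsubstituted phenyl, seen as a number 15.1 percentage points higher from compound 1 to compound 3 (beyond the scatter) on the same read-out. Nothing available explains why the two placements differ. Open, as far as these compounds go, is whether a group such as ethoxy, hydroxy or chlorine on the same ring would match the methoxy in compound 2. Also open, from the compounds shown here alone, is how 3-methoxyphenyl would compare.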